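The source may report more compounds than this note shows. Statements on the series, on what has been measured and on what is new or still open speak of the compounds shown alone.

Measured compounds in the series:
compound 1 `COc1ccc(Cc2cc(-c3ccc(OC)cc3)nn(CC(=O)Nc3ccc(Br)cc3)c2=O)cc1` — > 50000 nM
compound 2 `Cc1cc(Cc2ccccc2)c(=O)n(CC(=O)Nc2ccc(Br)cc2)n1` — > 50000 nM
compound 3 `Cc1cc(Cc2ccccc2)c(=O)n(CC(=O)Nc2ccc(F)cc2)n1` — > 50000 nM

In an assay on HL-60 cells for agonist activity at N-formyl peptide receptor 3 (Homo sapiens), read by calcium flux (a higher number here means that more compound is needed for the effect, a lower number that less compound is needed), compound 1 gives > 50000 nM, which is a limit of the assay and not a number. Compound 2 likewise gives only a limit, > 50000 nM in this assay. Compound 3 gives > 50000 nM, again a limit. Compound 2 therefore stands nowhere definite on the numbers shown: its value in this assay is a limit, and the other two values shown are limits as well, (the limit of > 50000 nM in this assay, at which 3 of the 3 values shown sit).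

Among the measured compounds shown here, the step from compound 2 to compound 3 in this assay is a step that the two limits leave unreadable from compound 2 to compound 3, so no measured step has a readable size.

Compound 4 `COc1cc(Cc2cc(C)nn(CC(=O)Nc3ccc(Br)cc3)c2=O)cc(OC)c1` is not yet measured. It differs from compound 2 by 3,5-dimethoxyphenyl in place of phenyl on a saturated chain carbon bound to an aromatic carbon. For the measured compounds named here, no measured step involves this change, and the one step that exists gives no size. Going by the values given here, the only evidence is that all three values shown sit at the limit, (the limit of > 50000 nM in this assay, at which 3 of the 3 values shown sit). The expected step from compound 2 to compound 4 in this assay is therefore a number no higher from compound 2 to compound 4 (the limit leaves the size open), meaning that compound 4 is also expected to reach only the limit. The estimate for compound 4 in this assay is 50000 nM, within 15000 nM to 200000 nM.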

Compound 4, half-maximal effective concentration: > 50000 nM
Compound 4: only a limit was reported (the forecaster's own chance of this, stated with the estimate: 80%); the middle value sits exactly at the limit.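

In this assay compound 4 gives > 50000 nM, a limit and not a number. Among the compounds shown here, compound 2 also gives only a limit, and no step between it and compound 4 can be read. The compounds shown leave open whether any change to the shared core gives a readable value in this assay: the limit of > 50000 nM in this assay, at which 4 of the 4 values shown sit.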